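The source may hold more compounds than are shown below. What is called first, only, known or untested is meant among the compounds shown, and "the series" means these compounds.

Measured so far in a functional assay on MCF7 cells (Homo sapiens) for inhibition; a lower number here means a stronger inhibitor, a higher number a weaker inhibitor:

Compound 1, `CC/C(=C(/c1ccc(/C=C/C(=O)O)cc1)c1cc2ccccc2[nH]1)c1ccc(C#N)cc1`, gives 278 nM.
Compound 2, `CC/C(=C(/c1ccc(/C=C/C(=O)O)cc1)c1cc2ccccc2[nH]1)c1ccc(F)cc1Cl`, gives 39 nM.
Compound 3, `CC/C(=C(/c1ccc(/C=C/C(=O)O)cc1)c1cc2ccccc2[nH]1)c1c(C)cccc1Cl`, gives 30 nM.

Compound 3 has the lowest number of the three. Its gap to compound 2 is small, a 1.3-fold lower number from compound 2 to compound 3 (0.11 log units; within the scatter), so the two cannot be told apart, while its gap to compound 1 is clear, a 9.3-fold lower number from compound 1 to compound 3 (0.97 log units; beyond the scatter).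

Compound 4, `CC/C(=C(/c1ccc(/C=C/C(=O)O)cc1)c1cc2ccccc2[nH]1)c1ccc(Cl)c(C(F)(F)F)c1`, differs from compound 3 in one place: 4-chloro-3-(trifluoromethyl)phenyl in place of 2-chloro-6-methylphenyl on a double-bonded chain carbon bound to a double-bonded chain carbon and a saturated chain carbon. The shared core, including the indole, the acid-bearing chain and the ethyl, stays the same.

Two earlier steps bear on this. Replacing 4-cyanophenyl by 2-chloro-4-fluorophenyl gave a 7.1-fold lower number from compound 1 to compound 2 (0.85 log units; beyond the scatter), and replacing it by 2-chloro-6-methylphenyl gave a 9.3-fold lower number from compound 1 to compound 3 (0.97 log units; beyond the scatter). Both gains came from rings substituted as in the names 2-chloro-4-fluorophenyl and 2-chloro-6-methylphenyl; the ring entering in compound 4, 4-chloro-3-(trifluoromethyl)phenyl, resembles the 4-cyanophenyl of compound 1 more closely in where its groups stand. Among the compounds with values here, the number is therefore expected to rise, as a 4.0-fold higher number from compound 3 to compound 4 (0.60 log units; beyond the scatter), though only three compounds support this. For compound 4 the estimate in this assay is 120 nM, in the range 40 nM to 400 nM.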

Compound 4, half-maximal inhibitory concentration: 2200 nM
Beside the measured number, compound 4's estimate is 18-fold (1.26 log units) below it; the whole stated range lies below it.
By their numbers in this assay, from the lowest: compounds 3 and 2 (each within the scatter of the next); then compound 1; then compound 4.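

In this assay, within the data shown here, this position proves far less forgiving than the earlier compounds suggested: bringing in 4-chloro-3-(trifluoromethyl)phenyl gives a 73-fold higher number from compound 3 to compound 4 (1.87 log units; beyond the scatter) and a 56-fold higher number from compound 2 to compound 4 (1.75 log units; beyond the scatter), both large steps, whereas the earlier steps at this place were at most modest. The new ring also does worse than 4-cyanophenyl, with a 7.9-fold higher number from compound 1 to compound 4 (0.90 log units; beyond the scatter), so compound 1 no longer has the highest number, and a chlorine on the ring does not by itself keep the number low, since compound 4 carries one as well as compound 2 and compound 3. Nothing available here explains why this ring raises the number so sharply.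

The compounds shown leave open whether the rise follows the trifluoromethyl, the chlorine or only the two together, as no ring here carries just one of them as named in 4-chloro-3-(trifluoromethyl)phenyl. They also leave open how a ring bearing a methoxy group or an amine would behave at this position, and whether any such ring could reach the low numbers of compound 2 and compound 3.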